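Sulfonamide-to-amide swap on the lactam series

The compounds below may be only part of what the source reports. "The series", "measured", "known", "first", "only" and "open" are said of these compounds alone.

Three compounds of one series have numbers in an assay on cells for inhibition of cytochrome P450 11B2, mitochondrial (Homo sapiens), read by HTRF; a higher number here means a weaker inhibitor, a lower number a stronger inhibitor. Compound 1, `O=C1c2ccc(Cl)cc2C(C2CC2)N1c1cccnc1`, gives 161 nM. Compound 2, `CCC(=O)N[C@@H]1CCCc2c1cncc2N1CCc2cc(Cl)ccc2C1=O`, gives 119 nM. Compound 3, `CCS(=O)(=O)NCc1cncc(N2C(=O)c3ccc(Cl)cc3C2(C)C)c1`, gives 92 nM, the lowest of the three numbers; the gap to compound 2 and the gap to compound 1 both sit within the usual scatter of this assay, so no order among the three can be read from these values.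

Compound 4, `CCC(=O)NCc1cncc(N2C(=O)c3ccc(Cl)cc3C2(C)C)c1`, has not yet been measured in this assay. It differs from compound 3 in one place: propanoyl in place of ethylsulfonyl on an amine nitrogen. Ethylsulfonyl leaves, propanoyl enters, on the amine nitrogen of the (ethylsulfonyl)amino methyl chain; the rest of the molecule is unchanged. Within the data shown here, no pair of measured compounds shows this exact step, so its size must be guessed. Compound 2 carries a propanoylamino group on a different part of its frame and gives 119 nM, close to compound 3, which speaks for a small effect of this group. The step from compound 3 to compound 4 is expected to be small, a 1.3-fold higher number from compound 3 to compound 4 (0.12 log units; within the scatter), in either direction but most likely not beyond the scatter. Compound 4 is estimated at 120 nM in this assay, with a range from 55 nM to 260 nM.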

Compound 4, half-maximal inhibitory concentration: 282 nM
The estimate for compound 4 lay 2.4-fold (0.37 log units) below the measured number, and the stated range ends below it.
By their numbers in this assay, from the lowest: compounds 3, 2, 1 and 4 (each within the scatter of the next, the first and the last beyond it).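

In this assay, among these compounds, the group on this amine nitrogen does matter: the change to propanoyl from ethylsulfonyl gives a 3.1-fold higher number from compound 3 to compound 4 (0.49 log units; beyond the scatter), and this is the only one-place step so far. The earlier compounds shown here could not show this, as they lay within the scatter of one another and differ from each other in more than one place, so the propanoylamino group of compound 2 gave no reading of this exchange on the frame shared by compound 3 and compound 4. No measurement on hand bears on what lies behind the step.

From the compounds shown here alone, it remains open whether a methylsulfonyl group or a longer alkylsulfonyl chain on this nitrogen would stay close to compound 3, and whether a sulfamide or a urea there would fall nearer to compound 3 or to compound 4. Going by these compounds, it is also open whether the reverse exchange, ethylsulfonyl in place of propanoyl on the frame of compound 2, would carry a step of similar size.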